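A few compounds are considered here, and "the series" means these few. Any claim that something is new, unique, unknown or untested is made for them only; others in the source may bear on it.

Measured so far:
- compound 1 `O=c1[nH]cnc2c1c(-c1ccoc1)cn2[C@@H]1O[C@H](CO)[C@@H](O)[C@H]1O`: 12100 nM
- compound 2 `O=c1[nH]cnc2c1c(-c1ccsc1)cn2[C@@H]1O[C@H](CO)[C@@H](O)[C@H]1O`: > 15000 nM
- compound 3 `CNc1ncnc2c1c(-c1ccsc1)cn2[C@@H]1O[C@H](CO)[C@@H](O)[C@H]1O`: > 20000 nM

In a functional assay on HepG2 cells (Homo sapiens) for antiproliferative activity, read by XTT assay, with a stated time of 72 h (a higher number here means a weaker inhibitor, a lower number a stronger inhibitor), compound 1 gives 12100 nM. For compound 2 the reading is only a limit, > 15000 nM. For compound 3 the reading is likewise only a limit, > 20000 nM.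

Compound 2 and compound 1 differ in one place: furan-3-yl in place of thiophen-3-yl on an aromatic carbon. The step is an at least 1.2-fold lower number from compound 2 to compound 1 (0.09 log units; that floor lies within the scatter), and it is known only as a floor because the limit of > 15000 nM in this assay, at which 1 of the 3 values shown sits, stands for compound 2 rather than a number. Whether the true step is larger cannot be told from these two readings.

Compound 3 and compound 2 share the same change of ring at the same place but differ in their cores; the difference between the two cores is not broken down here.

Compound 4 `CNc1ncnc2c1c(-c1ccoc1)cn2[C@@H]1O[C@H](CO)[C@@H](O)[C@H]1O` is not yet measured. Going by the values given here, it differs from compound 3 by furan-3-yl in place of thiophen-3-yl on an aromatic carbon, the same change, at a place described in the same words, as the one from compound 2 to compound 1.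

Among the compounds with values here, for compound 4 the expected step is a number no higher from compound 3 to compound 4 (the limit leaves the size open), set beside an at least 1.2-fold lower number from compound 2 to compound 1 (0.09 log units; that floor lies within the scatter), since compound 3 itself sits at a limit, (the limit of > 20000 nM in this assay, at which 1 of the 3 values shown sits), and the one measured instance of the change moved the number by no more than a floor within the scatter. Compound 4 is expected near 20000 nM, with the range 9000 nM to 45000 nM, and a limit reading is thought the likelier outcome in this assay.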

Compound 4, half-maximal inhibitory concentration: > 20000 nM
Compound 4: a limit, no number; the forecaster's own chance of this, stated with the estimate: 65%; the middle value lies on the limit itself.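

The step from compound 3 to compound 4 cannot be read, because both compounds return a limit rather than a number, and the same limit at that: the limit of > 20000 nM in this assay, at which 2 of the 4 values shown sit. The compounds shown leave open how far compound 3 and compound 4 lie past that limit, and whether furan-3-yl in place of thiophen-3-yl moves the number at all on their shared core.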